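2-Methoxyphenyl to 4-fluorophenyl: expecting a small step

A few compounds are considered here, and "the series" means these few. Any claim that something is new, unique, unknown or untested is made for them only; others in the source may bear on it.

Two related compounds have been tested so far. In a functional assay on THP-1 cells (Homo sapiens) for inhibition, with a stated time of 48 h, tested at 50 uM (on this read-out higher numbers stand for more inhibition of growth at the one concentration tested and lower numbers for less inhibition of growth), compound 1 (`C=C[C@@](C)(/C=C/c1ccc(O)c([N+](=O)[O-])c1)CCC=C(C)C`) gives 55%, and compound 2 (`COc1ccccc1/C=C/[C@@](C)(/C=C/c1ccc(O)cc1)CCC=C(C)C`) gives 62%. These two numbers lie within the usual scatter of repeated measurements, so compound 2 stands level with compound 1 and neither can be ranked ahead of the other.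

The next compound, compound 3 (`CC(C)=CCC[C@](C)(/C=C/c1ccc(O)cc1)/C=C/c1ccc(F)cc1`), has not yet been measured. It differs from compound 2 in one place, with 4-fluorophenyl in place of 2-methoxyphenyl on a double-bonded chain carbon bound to a double-bonded chain carbon. Among the measured compounds shown here, compound 1 and compound 2 differ in more than one place, so no measured pair shows what this swap does, and the data offer no firm direction. The natural starting point is therefore compound 2 at 62%. In this assay the expected change is small, a number 4 percentage points lower from compound 2 to compound 3 (within the scatter), and no step beyond the scatter is anticipated. Compound 3 is expected to give 58%, with an estimated range from 42% to 74%.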

Compound 3, percent growth inhibition at one concentration: 60%
For compound 3 the middle estimate is 2 percentage points below the measured one; the measured number falls inside the stated range.
By their numbers in this assay, from the lowest: compounds 1, 3 and 2 (each within the scatter of the next).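

Among the compounds shown here, compound 2 and compound 3 give the first measured swap at this position, on a double-bonded chain carbon bound to a double-bonded chain carbon. In this assay, putting 4-fluorophenyl in place of 2-methoxyphenyl gives a number 2 percentage points lower from compound 2 to compound 3 (within the scatter), so this read-out does not separate the two groups, even though the hydrogen-bond acceptor counted on 2-methoxyphenyl is absent from 4-fluorophenyl. Nothing measured here accounts for this result or says whether the two groups act alike in the cells for the same reason.

For the compounds shown here, this one pair covers only two aromatic rings of carbon at this position, so it remains open whether the tolerance extends to a 4-aminophenyl group, a 4-carboxyphenyl group or a longer chain in place of the ring. A reading at one concentration also leaves open whether compound 2 and compound 3 would stay level across a range of concentrations, which is the kind of comparison that could show a difference hidden within the scatter of a single reading.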